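The source may report more compounds than this note shows. Statements on the series, on what has been measured and on what is new or still open speak of the compounds shown alone.

Measured in a toxicity assay on Huh-7 cells (Homo sapiens) for cytotoxicity, with a stated time of 3 days; on this read-out lower numbers stand for higher toxicity in this test and higher numbers for lower toxicity in this test:
- compound 1 `C[C@@]1(O)[C@H](O)[C@@H](CO)O[C@H]1n1cc(I)c2c(N)ncnc21`: 19800 nM
- compound 2 `COc1ccc(-c2cn([C@@H]3O[C@H](CO)[C@@H](O)[C@@]3(C)O)c3ncnc(N)c23)cc1`: > 44000 nM
- compound 3 `C[C@@]1(O)[C@H](O)[C@@H](CO)O[C@H]1n1cc(-c2ccc3ccccc3c2)c2c(N)ncnc21`: 20100 nM

Compound 2 is reported only as a limit, not as a number: the limit of > 44000 nM in this assay, at which 1 of the 3 values shown sits. Compound 4 `C[C@@]1(O)[C@H](O)[C@@H](CO)O[C@H]1n1cc(-c2ccco2)c2c(N)ncnc21` carries furan-2-yl in place of 4-methoxyphenyl on an aromatic carbon.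

Three measured steps at this carbon bear on the change. Putting 4-methoxyphenyl in place of iodo gives an at least 2.2-fold higher number from compound 1 to compound 2 (0.34 log units; beyond the scatter). Putting naphthalen-2-yl in place of 4-methoxyphenyl gives an at least 2.1-fold lower number from compound 2 to compound 3 (0.34 log units; beyond the scatter). Both are modest and rest on the limit. Putting naphthalen-2-yl in place of iodo gives a 1.0-fold higher number from compound 1 to compound 3 (0.01 log units; within the scatter), within the scatter. Going by the values given here, compound 2 is thus the only one of the three at the limit, and no furan-2-yl compound has been measured.

Leaving 4-methoxyphenyl is therefore expected to lower the number modestly, as with compound 3 at 20100 nM. A further limit remains possible. The expected step is an at least 1.6-fold lower number from compound 2 to compound 4 (0.22 log units; that floor lies within the scatter). For compound 4 the estimated value is 26000 nM, with an expected range from 11000 nM to 60000 nM.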

Compound 4, half-maximal cytotoxic concentration: 49600 nM
The estimate for compound 4 lay 1.9-fold (0.28 log units) below the measured number; measured number inside the range.
By their numbers in this assay, from the lowest: compounds 1 and 3 (each within the scatter of the next); then compound 4.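

In this assay furan-2-yl moves the number up against both other groups with measured numbers at this aromatic carbon, with a 2.5-fold higher number from compound 3 to compound 4 (0.39 log units; beyond the scatter) and a 2.5-fold higher number from compound 1 to compound 4 (0.40 log units; beyond the scatter), both modest. Going by these compounds alone, this is the first separation beyond the scatter at this carbon between two measured numbers, as iodo and naphthalen-2-yl gave values within the scatter of each other and the earlier separations rested on compound 2. The step between compound 2 and compound 4 cannot be read, compound 2 being reported only as a limit and not a number: the limit of > 44000 nM in this assay, at which 1 of the 4 values shown sits.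

Going by these compounds, whether the higher number belongs to furan-2-yl alone or extends to other five-membered aromatic rings remains open. Also open, on these data alone, is how a group without an aromatic ring at this carbon, such as an amine, a carboxylic acid or a longer chain, would read.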